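The source may report more compounds than this note shows. Statements on the series, on what has been measured and on what is new or still open speak of the compounds shown alone.

Compound 1 `N=C(NCCCc1c[nH]cn1)NCCC(c1ccccc1)c1ccccn1` gives 7.39 in a functional assay on cardiac atrium for agonist activity at histamine H2 receptor (Cavia porcellus); on this read-out lower numbers stand for lower potency and higher numbers for higher potency (the scale is a negative logarithm).
Compound 2 `N=C(NCCCc1c[nH]cn1)NCCC(c1ccc(F)cc1)c1ccccn1` gives 8.01 in this assay.
Compound 3 `N=C(NCCCc1c[nH]cn1)NCCC(c1ccc(Br)cc1)c1ccccn1` gives 7.48 in this assay.

Among these three numbers, compound 3 lies within the usual scatter of compound 1 and clearly below compound 2. Compound 4 `N=C(NCCCc1c[nH]cn1)NCCC(c1ccc(C(F)(F)F)cc1)c1ccccn1` differs from compound 3 by trifluoromethyl in place of bromo on an aromatic carbon. Within the data shown here, no measured step exchanges bromo for trifluoromethyl. The steps at this position are a number 0.09 log units higher from compound 1 to compound 3 (within the scatter) and a number 0.53 log units lower from compound 2 to compound 3 (beyond the scatter), while a number 0.62 log units higher from compound 1 to compound 2 (beyond the scatter) runs the other way. Because compound 1 and compound 3 differ only by a number 0.09 log units higher from compound 1 to compound 3 (within the scatter), a group at this place need not shift the number much. Compound 4 is therefore expected to stay near compound 3, with an expected step of a number 0.08 log units lower from compound 3 to compound 4 (within the scatter). The estimate for compound 4 is 7.4, ranging from 6.9 to 7.9.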

Compound 4, negative logarithm of the half-maximal effective concentration: 7.76
Beside the measured number, compound 4's estimate is 0.36 log units below it; measured number inside the range.
By their numbers in this assay, from the lowest: compounds 1, 3, 4 and 2 (each within the scatter of the next, the first and the last beyond it).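

Trifluoromethyl at this place separates from hydrogen, with a number 0.37 log units higher from compound 1 to compound 4 (beyond the scatter) as the step, so fluoro is no longer the only group shown to lift the number above that of compound 1. Yet a number 0.28 log units higher from compound 3 to compound 4 (within the scatter) and a number 0.25 log units lower from compound 2 to compound 4 (within the scatter) both lie within the scatter, so compound 4 cannot be told apart from either halogen compound, although those two differ from each other. Nothing available explains this pattern.

As far as these compounds go, whether an amine, a methoxy group or a carboxylic acid at this place would also stand clear of compound 1 remains open.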